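Cytotoxicity notes on the series: compound 3 to compound 4

The source may report more compounds than this note shows. Statements on the series, on what has been measured and on what is new or still open speak of the compounds shown alone.

Measured so far in an ADME assay on HEp-2 cells (Homo sapiens) for cytotoxicity; on this read-out higher numbers stand for lower toxicity in this test and lower numbers for higher toxicity in this test:
- compound 1, `N#CCCCn1c(Cn2c(=O)n(Cc3ccc(C#N)cc3)c3ccncc32)nc2ccccc21`: 36800 nM
- compound 2, `CC(C)S(=O)(=O)n1c(=O)n(Cc2nc3ccccc3n2CCCC#N)c2cnccc21`: a limit of the assay only, > 228000 nM
- compound 3, `N#CCCCn1c(Cn2c(=O)n(C3CCC3)c3ccncc32)nc2ccccc21`: a limit of the assay only, > 258000 nM

Among the measured compounds shown here, compound 3 stands at a limit of this assay rather than at a number, and compound 2 is the one further value that is also a limit (the limit of > 228000 nM in this assay, at which 1 of the 3 values shown sits; (the limit of > 258000 nM in this assay, at which 1 of the 3 values shown sits)). For the measured compounds named here, compound 1 is the only compound with a read number.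

The steps read as follows: an at least 6.1-fold higher number from compound 1 to compound 2 (0.79 log units; beyond the scatter); an at least 7.0-fold higher number from compound 1 to compound 3 (0.84 log units; beyond the scatter); a step that the two limits leave unreadable from compound 2 to compound 3.

Compound 4, `N#CCCCn1c(Cn2c(=O)n(C(F)F)c3ccncc32)nc2ccccc21`, is not yet measured. Its change from compound 3 is difluoromethyl in place of cyclobutyl on an aromatic nitrogen. Going by the values given here, no measured step exchanges one small group for another on this nitrogen with a readable result; the step from compound 2 to compound 3 is the closest and is unreadable. The two readable steps show only that leaving 4-cyanobenzyl raises the number in this assay at least modestly. Compound 4 keeps a small group there, so no step beyond the scatter is expected, and a limit is again likely.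

Compound 4 is therefore expected at 200000 nM, range 50000 nM to 400000 nM. The expected step is an at least 1.2-fold lower number from compound 3 to compound 4 (0.11 log units; that floor lies within the scatter).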

Compound 4, half-maximal cytotoxic concentration: > 205000 nM
Compound 4 ended at the assay's limit; the forecaster's own chance of this, stated with the estimate: 55%; middle value at least 1.0-fold (0.01 log units) from the limit.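

Compound 4 stands at a limit of this assay, > 205000 nM, and gives no read number. Among the compounds shown here, putting difluoromethyl in place of 4-cyanobenzyl on this aromatic nitrogen gives an at least 5.5-fold higher number from compound 1 to compound 4 (0.74 log units; beyond the scatter), so a fluorine-bearing group with no ring now joins isopropylsulfonyl and cyclobutyl among the three replacements that each give a step beyond the scatter, with compound 1 remaining the only compound with a read number. The steps among compounds 2, 3 and 4 cannot be read, since all three values are limits, and the change from cyclobutyl to difluoromethyl therefore gives no order among these groups.

The compounds shown leave open how far a read number in this assay depends on the aromatic ring of 4-cyanobenzyl and how far on its nitrile, a question that plain benzyl on the same nitrogen would address. They also leave open whether an amine, a carboxylic acid or a longer alkyl chain at this position would stay at a limit or give a read number.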